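This account rests on a few compounds, and the source may have more. Where it says the series, first, only, none or still open, it means among the compounds named here.

In an ADME assay on a cell-free system (plasma, Homo sapiens) for metabolic stability, with Plasma (Rattus norvegicus) as the target, read by HPLC, at pH 7.4 (on this read-out lower numbers stand for a shorter-lived compound and higher numbers for a longer-lived compound), the measured compounds stand as follows:

Compound 1 `CC(=O)Oc1ccccc1C(=O)O[C@H]1CO[C@H]2[C@@H]1OC[C@H]2OC(C)=O` gives 0.0608 h.
Compound 2 `CCC(=O)O[C@@H]1CO[C@H]2[C@@H]1OC[C@@H]2OC(=O)c1ccccc1OC(C)=O` gives 0.0608 h.
Compound 3 `CC(=O)Oc1ccccc1C(=O)O[C@H]1CO[C@H]2[C@@H]1OC[C@H]2OC(=O)c1ccccc1C` gives 0.035 h.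

Compound 2 stands level with compound 1 at the digits shown, the two together being the highest of the three numbers; its gap to compound 3 is a 1.7-fold lower number from compound 2 to compound 3 (0.24 log units; within the scatter). Compound 4 `CC(=O)Oc1ccccc1C(=O)O[C@H]1CO[C@H]2[C@@H]1OC[C@H]2OC(=O)c1ccc(-c2ccccc2)cc1` differs from compound 2 in one place: 4-phenylphenyl in place of ethyl on a carbonyl carbon. Within the data shown here, the steps that bear on this are a 1.7-fold lower number from compound 2 to compound 3 (0.24 log units; within the scatter) and a 1.7-fold lower number from compound 1 to compound 3 (0.24 log units; within the scatter), in which a 2-methylphenyl replaced ethyl or methyl on the same carbonyl carbon and the number scarcely moved. A 4-phenylphenyl now enters at that place, so the expected step in this assay is a 1.4-fold lower number from compound 2 to compound 4 (0.13 log units; within the scatter), at most a small downward shift. Compound 4 is therefore estimated at 0.045 h, with a range from 0.02 h to 0.1 h.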

Compound 4, half-life: > 0.333 h
Compound 4: only a limit was reported; the forecaster's own chance of this, stated with the estimate: 5%; middle value at least 7.4-fold (0.86 log units) from the limit.
By their numbers in this assay, from the lowest: compounds 3, 1 and 2 (each within the scatter of the next). At a limit, above all of these: compound 4.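

In this assay, methyl, ethyl and 2-methylphenyl on this carbonyl carbon stayed within the scatter of one another, but 4-phenylphenyl brings a clear rise: an at least 5.4-fold higher number from compound 2 to compound 4 (0.73 log units; beyond the scatter), an at least 5.4-fold higher number from compound 1 to compound 4 (0.73 log units; beyond the scatter) and an at least 9.5-fold higher number from compound 3 to compound 4 (0.97 log units; beyond the scatter). So the group at this place can strongly change how long the compound lasts. The reading for compound 4 is a limit, not a number: the limit of > 0.333 h in this assay, at which 1 of the 4 values shown sits.

As far as these compounds go, how far compound 4 truly lies past that limit remains open. Also open, from the compounds shown here alone, is whether a plain phenyl or a longer chain on this carbonyl carbon would give a similar rise.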